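The compounds below may be only part of what the source reports. "The series", "measured", "known", "first", "only" and "open" are said of these compounds alone.

Measured compounds:
- Compound 1 `Cc1cccc(-n2cc(-c3cccc(NS(=O)(=O)c4c[nH]c(=O)[nH]c4=O)c3)nn2)c1` gives 3550 nM in a functional assay on A549 cells (Homo sapiens) for antiproliferative activity, read by MTT assay, with a stated time of 24 h; a lower number here means a stronger inhibitor, a higher number a weaker inhibitor
- Compound 2 `Cc1ccc(-n2cc(-c3cccc(NS(=O)(=O)c4c[nH]c(=O)[nH]c4=O)c3)nn2)cc1` gives 3630 nM in this assay

Among the measured compounds shown here, compound 2 has the highest of the two numbers so far, but the step of a 1.0-fold higher number from compound 1 to compound 2 (0.01 log units; within the scatter) shows that moving the methyl group around the phenyl ring left the number essentially where it was. Compound 3 `O=c1[nH]cc(S(=O)(=O)Nc2cccc(-c3cn(-c4ccccc4F)nn3)c2)c(=O)[nH]1` has not yet been measured. Its change from compound 2 is 2-fluorophenyl in place of 4-methylphenyl on an aromatic nitrogen. For the measured compounds named here, the only measured step, a 1.0-fold higher number from compound 1 to compound 2 (0.01 log units; within the scatter), bears on it indirectly: it shows that the phenyl group on the aromatic nitrogen tolerated one alteration without a shift beyond the scatter. Going by the values given here, no step swaps a methyl for a fluorine, so the expectation rests on that single comparison. The expected step is a 1.0-fold lower number from compound 2 to compound 3 (0.00 log units; within the scatter), that is, no change beyond the scatter. Compound 3 is therefore estimated at 3600 nM, with a range from 1500 nM to 9000 nM.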

Compound 3, half-maximal inhibitory concentration: > 20000 nM
Compound 3: no number, only a limit; the forecaster's own chance of this, stated with the estimate: 5%; at least 5.5-fold (0.74 log units) between middle value and limit.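

The phenyl group on the aromatic nitrogen proves less forgiving than the earlier pair suggested: in this assay, 2-fluorophenyl in place of 4-methylphenyl gives an at least 5.5-fold higher number from compound 2 to compound 3 (0.74 log units; beyond the scatter), and in place of 3-methylphenyl it gives an at least 5.6-fold higher number from compound 1 to compound 3 (0.75 log units; beyond the scatter). From the compounds shown here alone, compound 3 carries only a limit of the assay, not a number, so the full size of both steps stays unknown: the limit of > 20000 nM in this assay, at which 1 of the 3 values shown sits. The methyl group leaves and a fluorine enters in a single step, and the result does not tell which of the two matters.

Still open, going by these compounds, is whether plain phenyl, 3-fluorophenyl or 4-fluorophenyl would read like compound 3 or like compound 1 and compound 2. Also open, on these data alone, is how an amine or a carboxylic acid on that phenyl ring would behave.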